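A Dimethoxy Swap on a Weakly Active Cell Inhibitor

The source may report more compounds than this note shows. Statements on the series, on what has been measured and on what is new or still open speak of the compounds shown alone.

Compound 1 `C=C(Br)C(=O)Nc1cccc(-c2cn3nc(-c4ccc(CC)cc4)sc3n2)c1` carries a 4-ethylphenyl group on its shared core. In a functional assay on HeLa cells (Homo sapiens) for inhibition, read by cell counting, with a stated time of 4 days (on this read-out lower numbers stand for stronger inhibition and higher numbers for weaker inhibition), compound 1 gives 3200 nM, the lowest of the two numbers at hand. Compound 2 `COc1ccc(-c2csc3nc(-c4cccc(N)c4)cn23)cc1` gives 19000 nM in this assay; the gap between these two values lies beyond the usual scatter, so compound 1 stands as the stronger of the pair. Compound 3 `C=C(Br)C(=O)Nc1cccc(-c2cn3nc(-c4ccc(OC)c(OC)c4)sc3n2)c1` differs from compound 1 in one place: 3,4-dimethoxyphenyl in place of 4-ethylphenyl on an aromatic carbon. Among the compounds with values here, no measured pair shows what such a swap does here, so the expectation rests on compound 1 alone. The change is expected to be small, a 1.1-fold higher number from compound 1 to compound 3 (0.04 log units; within the scatter), with no clear direction and likely not beyond the scatter. Compound 3 is therefore estimated at 3500 nM in this assay, within a range of 1000 nM to 12000 nM.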

Compound 3, half-maximal inhibitory concentration: 610 nM
Beside the measured number, compound 3's estimate is 5.7-fold (0.76 log units) above it; the measured number lies below the stated range.
By their numbers in this assay, from the lowest: compound 3; then compound 1; then compound 2.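

Placing 3,4-dimethoxyphenyl in place of 4-ethylphenyl on the aromatic carbon next to the ring sulfur gives, in this assay, a 5.2-fold lower number from compound 1 to compound 3 (0.72 log units; beyond the scatter). Within the data shown here, this is the first direct sign that the group at this position matters to the read-out, which compound 1 and compound 2 could not show, as they differ in more than one place. Nothing available explains why the number falls with this change.

The swap removes the ethyl group and brings in both methoxy groups at once, leaving open whether a single methoxy group would give the same step. From the compounds shown here alone, it also remains open how the read-out would respond to a different group on this phenyl ring, such as an amine or a carboxylic acid.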